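The compounds below may be only part of what the source reports. "The series", "measured", "known", "first", "only" and "open" are said of these compounds alone.

In a functional assay on HL-60 cells (Homo sapiens) for inhibition, read by MTT assay, with a stated time of 48 h, tested at 10 uM (a lower number here means less inhibition of growth, a higher number more inhibition of growth at the concentration tested), three compounds sharing one core have been measured. Compound 1 (`Cc1cc(=O)c2c(O)c(CN3CCCC3)c(O)c([C@H]3CCN(C)C[C@H]3O)c2o1`) gives 38%, compound 2 (`Cc1cc(=O)c2c(O)c(CN3CCCC3CO)c(O)c([C@H]3CCN(C)C[C@H]3O)c2o1`) gives 33%, and compound 3 (`CCOC(=O)N1CCN(Cc2c(O)c([C@H]3CCN(C)C[C@H]3O)c3oc(C)cc(=O)c3c2O)CC1`) gives 16%, the lowest of the three numbers. The other two do not separate, as a number 5 percentage points lower from compound 1 to compound 2 (within the scatter) shows.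

Compound 4 (`Cc1cc(=O)c2c(O)c(CN3CCCCC3)c(O)c([C@H]3CCN(C)C[C@H]3O)c2o1`) differs from compound 3 in one place, on a saturated chain carbon bound to an aromatic carbon: piperidin-1-yl in place of 4-(ethoxycarbonyl)piperazin-1-yl on a saturated chain carbon bound to an aromatic carbon. Within the data shown here, two measured steps bear on this change, since both bring in the 4-(ethoxycarbonyl)piperazin-1-yl group that compound 4 gives up. They are a number 22 percentage points lower from compound 1 to compound 3 (beyond the scatter) and a number 17 percentage points lower from compound 2 to compound 3 (beyond the scatter), each modest and beyond the scatter. Among the measured compounds shown here, no measured compound carries piperidin-1-yl, so the expectation rests on these two steps alone: a modest rise of similar size, in the opposite direction.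

The expected step is a number 19 percentage points higher from compound 3 to compound 4 (beyond the scatter). In this assay, the estimate for compound 4 is 35%, expected to fall between 23% and 47%.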

Compound 4, percent growth inhibition at one concentration: 32%
The estimate for compound 4 lay 3 percentage points above the measured number; low and high end bracket the measured number.
By their numbers in this assay, from the lowest: compound 3; then compounds 4, 2 and 1 (each within the scatter of the next).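

Piperidin-1-yl on a saturated chain carbon bound to an aromatic carbon gives a clear rise over 4-(ethoxycarbonyl)piperazin-1-yl (a number 16 percentage points higher from compound 3 to compound 4 (beyond the scatter)), so a group with no pyrrolidine ring also sits well above compound 3. In this assay, replacing pyrrolidin-1-yl or 2-(hydroxymethyl)pyrrolidin-1-yl with piperidin-1-yl does not separate the compounds (a number 6 percentage points lower from compound 1 to compound 4 (within the scatter); a number 1 percentage points lower from compound 2 to compound 4 (within the scatter)), which leaves compound 3 alone apart from the other three. Nothing available explains why compound 3 stands apart.

Going by these compounds, whether the lower number of compound 3 goes with the ethoxycarbonyl group or with the piperazine ring stays open. A piperazin-1-yl group with a free ring amine, or a morpholin-4-yl group, at this place would help to separate the two.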